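Changing the aryl group of compound 2

This account rests on a few compounds, and the source may have more. Where it says the series, first, only, none or still open, it means among the compounds named here.

- Compound 1 (`Cc1cc(NC(=O)NCCCC[C@@H](Nc2cc(C)c(F)c(C)c2)C(=O)NO)ccc1F`) gives < 3 as a limit
- Compound 2 (`Cc1cc(N[C@H](CCCCNCc2cccc(F)c2)C(=O)NO)cc(C)c1F`) gives < 3 as a limit

Both results come from a physicochemical assay for lipophilicity, at pH 7.4 (a higher number here means a more lipophilic compound, a lower number a more polar compound), and are limits of the assay, not numbers. Going by these compounds, compound 2 shares that mark with compound 1 (the limit of < 3 in this assay, at which 2 of the 2 values shown sit), so its exact position remains unknown.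

Compound 3 (`Cc1cc(N[C@H](CCCCNCc2ccc(C(F)(F)F)cc2)C(=O)NO)cc(C)c1F`) keeps the rest of compound 2 and differs in one place (4-(trifluoromethyl)phenyl in place of 3-fluorophenyl on a saturated chain carbon bound to an amine nitrogen): 4-(trifluoromethyl)phenyl in place of 3-fluorophenyl on a saturated chain carbon bound to an amine nitrogen. Going by the values given here, no pair of measured compounds shows what such a swap does, so what follows is a judgement. In this assay a small upward move is expected, not far beyond the usual scatter. The estimated step (a step that the limit leaves unreadable from compound 2 to compound 3) is therefore modest. The assay may again report only a limit. Compound 3 is expected at 2.7 (range 2.1 to 3.3).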

Compound 3, distribution coefficient: < 3
Compound 3 gave a limit, no number; the forecaster's own chance of this, stated with the estimate: 60%; the middle value is on the limit's open side.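

In this assay compound 3 gives < 3, again a limit and not a number. No step from compound 2 to compound 3 can be read, because both sit at the same mark: the limit of < 3 in this assay, at which 3 of the 3 values shown sit.

Going by these compounds, whether 4-(trifluoromethyl)phenyl in place of 3-fluorophenyl shifts the true value at all remains open.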